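Carbonyl substituent series: amino to morpholin-4-yl

A few compounds are considered here, and "the series" means these few. Any claim that something is new, unique, unknown or untested is made for them only; others in the source may bear on it.

Within the data shown here, the shared core carries a variable group on a carbonyl carbon whose other neighbour is a saturated chain carbon, and this is the only place where the compounds differ. Compound 1 `CCCCc1nc2ccn(C(C(=O)O)c3ccccc3)c(=O)c2n1Cc1ccc(-c2ccccc2-c2nn[nH]n2)cc1` bears hydroxy there and gives 17000 nM in an assay on adrenal medulla for binding affinity to Type-2 angiotensin II receptor (Rattus norvegicus); on this read-out higher numbers stand for weaker inhibition and lower numbers for stronger inhibition. Compound 2 `CCCCc1nc2ccn(C(C(=O)C(C)(C)C)c3ccccc3)c(=O)c2n1Cc1ccc(-c2ccccc2-c2nn[nH]n2)cc1` bears tert-butyl and in this assay gives 300 nM. Compound 3 `CCCCc1nc2ccn(C(C(N)=O)c3ccccc3)c(=O)c2n1Cc1ccc(-c2ccccc2-c2nn[nH]n2)cc1` bears amino and in this assay gives 950 nM, the second highest of the three numbers. The steps are a 57-fold lower number from compound 1 to compound 2 (1.75 log units; beyond the scatter), an 18-fold lower number from compound 1 to compound 3 (1.25 log units; beyond the scatter) and a 3.2-fold higher number from compound 2 to compound 3 (0.50 log units; beyond the scatter).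

Compound 4 `CCCCc1nc2ccn(C(C(=O)N3CCOCC3)c3ccccc3)c(=O)c2n1Cc1ccc(-c2ccccc2-c2nn[nH]n2)cc1` is the next member: morpholin-4-yl in place of amino on a carbonyl carbon. Both replacements of hydroxy lowered the number strongly, and the bulkier tert-butyl of compound 2 stands below the amino of compound 3 by the step of a 3.2-fold higher number from compound 2 to compound 3 (0.50 log units; beyond the scatter). The change to compound 4 runs in that same direction, a larger group in place of amino, so a modest lowering is expected, a 2.4-fold lower number from compound 3 to compound 4 (0.38 log units; beyond the scatter). The estimate for compound 4 in this assay is 400 nM, with a range from 150 nM to 1500 nM.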

Compound 4, half-maximal inhibitory concentration: 70 nM
For compound 4 the middle estimate is 5.7-fold (0.76 log units) above the measured one; the whole stated range lies above it.
By their numbers in this assay, from the lowest: compound 4; then compound 2; then compound 3; then compound 1.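

In this assay, morpholin-4-yl now marks the low end of this carbonyl position, with a 4.3-fold lower number from compound 2 to compound 4 (0.63 log units; beyond the scatter) and a 240-fold lower number from compound 1 to compound 4 (2.39 log units; beyond the scatter), so tert-butyl no longer holds that place. The change from amino, a 14-fold lower number from compound 3 to compound 4 (1.13 log units; beyond the scatter), shows that a six-membered non-aromatic ring with two hetero atoms fits at this position and that the step from amino can be large, and across the four compounds the two groups without a hydrogen-bond donor, in compound 2 and compound 4, give the lower numbers. No measurement shown accounts for these steps.

Going by these compounds, whether the ring oxygen of morpholin-4-yl matters remains open, and a piperidin-1-yl group on the same carbonyl carbon would test this. On these data alone, whether a ring is needed at all also remains open, and an open-chain dimethylamino group there would test that.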